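The source may hold more compounds than are shown below. What is called first, only, known or untested is meant among the compounds shown, and "the series" means these compounds.

Working notes on the series. In a functional assay on MCF7 cells (Homo sapiens) for antiproliferative activity, read by MTT assay, with a stated time of 48 h (on this read-out higher numbers stand for weaker inhibition and lower numbers for stronger inhibition), compound 1 (`Cc1ccc(-c2nnc(NC(=O)/C=C/c3ccc(C(F)(F)F)cc3)s2)cc1`) gives 1.1 ug/mL. Compound 2 (`COc1ccc(/C=C/C(=O)Nc2nnc(-c3ccc(C)cc3)s2)cc1`) gives 0.35 ug/mL, and compound 3 (`Cc1ccc(/C=C/C(=O)Nc2nnc(-c3ccc(C)cc3)s2)cc1`) gives 0.61 ug/mL. Compound 1 therefore stands beyond the scatter of compound 2 but within the scatter of compound 3.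

Compound 4 (`O=C(/C=C/c1ccc(C(F)(F)F)cc1)Nc1nnc(-c2ccccc2)s1`) has not yet been measured. Its change from compound 1 is hydrogen in place of methyl on an aromatic carbon, or 4-methylphenyl to phenyl.

The measured steps are a 3.1-fold lower number from compound 1 to compound 2 (0.50 log units; beyond the scatter), a 1.8-fold lower number from compound 1 to compound 3 (0.26 log units; within the scatter) and a 1.7-fold higher number from compound 2 to compound 3 (0.24 log units; within the scatter). Only the first lies beyond the scatter, and it is modest. All three exchange trifluoromethyl, methoxy or methyl at a site that stays unchanged between compound 1 and compound 4. None alters the 4-methylphenyl group, so the data hold no direct measure of this change.

As far as these compounds go, no step beyond the scatter is therefore expected in this assay, and the direction remains open. The expected step is a 1.1-fold higher number from compound 1 to compound 4 (0.04 log units; within the scatter). Compound 4 is estimated at 1.2 ug/mL, with an expected range of 0.45 ug/mL to 3 ug/mL.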

Compound 4, half-maximal inhibitory concentration: 1.52 ug/mL
The estimate for compound 4 lay 1.3-fold (0.10 log units) below the measured number, and the stated range covers the measured number.
By their numbers in this assay, from the lowest: compounds 2, 3, 1 and 4 (each within the scatter of the next, the first and the last beyond it).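

In this assay the series now has its first direct reading at the 4-methylphenyl group: hydrogen in place of methyl gives a 1.4-fold higher number from compound 1 to compound 4 (0.14 log units; within the scatter), with the trifluoromethyl group unchanged. Within the compounds shown, this position therefore tolerates loss of the methyl without a step beyond the scatter, whereas the earlier steps concerned only the exchange of trifluoromethyl, methoxy and methyl at the other site. No measurement at hand bears on the reason for this result.

The change is shown only with trifluoromethyl at the other site, so whether it carries over to compound 2 and compound 3 stays open. Also open, as far as these compounds go, is how an amine, a carboxylic acid or a longer chain would read at this place on the ring.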